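From Butyl to tert-Butyl: A Branched Test

The compounds below may be only part of what the source reports. "The series", "measured", "known", "first", "only" and "open" are said of these compounds alone.

Compound 1 `O=C1C2=C(C(=O)c3ncccc31)C1(CS2)NC(=O)N(c2ccc(Cl)cc2)C1=O` - 10 nM
Compound 2 `CCCc1ccc(N2C(=O)NC3(CSC4=C3C(=O)c3ncccc3C4=O)C2=O)cc1` - 2 nM
Compound 3 `CCCCc1ccc(N2C(=O)NC3(CSC4=C3C(=O)c3ncccc3C4=O)C2=O)cc1` - 190 nM

These three values come from a functional assay on CCRF-SB cells (Homo sapiens) for antiproliferative activity, read by MTT assay, with a stated time of 96 h (a lower number here means a stronger inhibitor, a higher number a weaker inhibitor), and share one core, differing only in a single group on the aromatic ring. Compound 3 sits at the top with 190 nM and is the weakest inhibitor of the three.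

Next in line is compound 4 `CC(C)(C)c1ccc(N2C(=O)NC3(CSC4=C3C(=O)c3ncccc3C4=O)C2=O)cc1` with the change tert-butyl in place of butyl on an aromatic carbon in which tert-butyl takes the place of butyl. The two groups have the same atoms, joined differently.

The closest evidence is a 95-fold higher number from compound 2 to compound 3 (1.98 log units; beyond the scatter) where methyl replaces hydrogen on a saturated chain carbon. That large step shows how much one small edit can matter in this series. The steps from the chloro compound point the same way: a 5.0-fold lower number from compound 1 to compound 2 (0.70 log units; beyond the scatter) and a 19-fold higher number from compound 1 to compound 3 (1.28 log units; beyond the scatter) are opposite in direction, so the number does not simply follow from having an alkyl group here. None of the three compounds carries a branched group, so the data offer no direct guide.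

The high number has so far appeared only with the butyl chain of compound 3, so a fall toward the other two is expected. The estimate is a 6.3-fold lower number from compound 3 to compound 4 (0.80 log units; beyond the scatter) and this remains an expectation. For compound 4 the estimated value is 30 nM with 5 nM to 200 nM as the expected range.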

Compound 4, half-maximal inhibitory concentration: 200 nM
Estimate against measurement, compound 4: 6.7-fold (0.82 log units) below, and the stated range covers the measured number.
By their numbers in this assay, from the lowest: compound 2; then compound 1; then compounds 3 and 4 (each within the scatter of the next).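

In this assay, replacing the butyl chain with tert-butyl, the same four carbons joined differently, gives a 1.1-fold higher number from compound 3 to compound 4 (0.02 log units; within the scatter), so branching this group makes no measurable difference, and the high number is not peculiar to the straight chain of compound 3. Compound 4 also lies far from the two stronger compounds, with a 100-fold higher number from compound 2 to compound 4 (2.00 log units; beyond the scatter) and a 20-fold higher number from compound 1 to compound 4 (1.30 log units; beyond the scatter), so the two four-carbon groups shown both stand well apart from the propyl and chloro groups at this place on the aromatic ring. Nothing available explains why the propyl compound and the two four-carbon compounds differ so widely, and the result itself gives no reason.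

As far as these compounds go, it remains open whether the gap depends on the size of the alkyl group or on something particular to propyl; isopropyl, the branched partner of propyl, would test branching at the potent end of the series, while ethyl and pentyl would extend the straight-chain comparison on either side. The compounds shown also say nothing about how an amine or a carboxylic acid would fare at this place.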